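Ester for Benzyl on a Triazole Amide: Cytotoxicity Outlook

This account rests on a few compounds, and the source may have more. Where it says the series, first, only, none or still open, it means among the compounds named here.

Three compounds have been measured in a functional assay on B16 cells (Mus musculus) for cytotoxicity, read by MTT assay, with a stated time of 48 h; a lower number here means a stronger inhibitor, a higher number a weaker inhibitor:

Compound 1, `C#Cc1cccc(NC(=O)c2cn(Cc3ccccc3)nn2)c1`: 14500 nM
Compound 2, `C#Cc1cccc(NC(=O)c2cn(CC(=O)OCC)nn2)c1`: 91000 nM
Compound 3, `C#Cc1ccc(NC(=O)c2cn(Cc3ccccc3)nn2)cc1`: > 100000 nM

Compound 1 and compound 2 share one core and differ by a single change, (ethoxycarbonyl in place of phenyl on a saturated chain carbon bound to an aromatic nitrogen). That change gave a 6.3-fold higher number from compound 1 to compound 2 (0.80 log units; beyond the scatter). Compound 3 has the same atoms as compound 1 joined differently; the difference between the two cores is not broken down here. The value of compound 3 is a limit of the assay, not a number. Compound 4, `C#Cc1ccc(NC(=O)c2cn(CC(=O)OCC)nn2)cc1`, has not yet been measured. It differs from compound 3 by ethoxycarbonyl in place of phenyl on a saturated chain carbon bound to an aromatic nitrogen, the same change at the same place as between compound 1 and compound 2. The step from compound 3 to compound 4 is expected to be a step that the limit leaves unreadable from compound 3 to compound 4, resting on a 6.3-fold higher number from compound 1 to compound 2 (0.80 log units; beyond the scatter). Compound 3 already sits at the limit of > 100000 nM in this assay, at which 1 of the 3 values shown sits, so compound 4 is expected to give 400000 nM, most likely reported as a limit again, with the range estimated from 100000 nM to 2000000 nM.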

Compound 4, half-maximal inhibitory concentration: > 100000 nM
Compound 4 ended at the assay's limit; the forecaster's own chance of this, stated with the estimate: 90%; the middle value lies beyond the limit too.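

In this assay, compound 3 and compound 4 both end at a limit rather than a number, so no step can be read between them: the limit of > 100000 nM in this assay, at which 2 of the 4 values shown sit.

The compounds shown leave open whether the change from benzyl to (ethoxycarbonyl)methyl has the same effect on the core of compound 3 as on the core of compound 1.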